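The source may report more compounds than this note shows. Statements on the series, on what has been measured and on what is new or still open speak of the compounds shown alone.

Compound 1, `Cc1ccc(OCCCCOc2ccc(C(=O)CC(C)(C)C)c(O)c2C)cc1C(=O)O`: 309 nM in an assay for positive allosteric modulation of metabotropic glutamate receptor 3 (Rattus norvegicus); on this read-out lower numbers stand for an effect already at smaller amounts and higher numbers for an effect only at larger amounts of compound
Compound 2, `CNC(=O)c1cc(OCCCCOc2ccc(C(=O)CC(C)(C)C)c(O)c2C)ccc1F`: 476 nM
Compound 3, `COc1cc(OCCCCOc2ccc(C(=O)CC(C)(C)C)c(O)c2C)cc(C(=O)O)c1`: 703 nM

In this assay compound 1 has the lowest number of the three. Compound 2 lies within the usual scatter of it, so the two cannot be told apart; compound 3 stands beyond the scatter, with a higher number. Compound 4, `COc1ccc(OCCCCOc2ccc(C(=O)CC(C)(C)C)c(O)c2C)cc1`, has not yet been measured. It differs from compound 1 in one place: 4-methoxyphenyl in place of 3-carboxy-4-methylphenyl on an oxygen on a saturated carbon. Going by the values given here, no measured pair shows this change, so its effect is unknown. The carboxylic acid that compounds 1 and 3 share is absent from compound 4, as is the methylamide of compound 2. A move to a higher number, beyond the scatter, is expected: a 4.9-fold higher number from compound 1 to compound 4 (0.69 log units; beyond the scatter). Compound 4 is accordingly estimated at 1500 nM, within a range from 500 nM to 5000 nM.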

Compound 4, half-maximal effective concentration: "not active" (no number reported)
Compound 4 has no reported number here, and the estimate cannot be compared.
By their numbers in this assay, from the lowest: compounds 1, 2 and 3 (each within the scatter of the next, the first and the last beyond it).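

In this assay, going by these compounds alone, compound 4 is reported as "not active" without a number, so no step from compound 1 can be read. The compounds shown leave open which part of the change from 3-carboxy-4-methylphenyl to 4-methoxyphenyl goes with this result, and no data at hand explain it.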